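Methylsulfanyl for methoxy in a series at the limit

A few compounds are considered here, and "the series" means these few. Any claim that something is new, unique, unknown or untested is made for them only; others in the source may bear on it.

Values in an ADME assay on Raji cells (Homo sapiens) for cytotoxicity, read by luminescence, with a stated time of 72 h; a higher number here means that more compound is needed for the effect, a lower number that less compound is needed
compound 1 `CCOC(=O)c1c(-c2cccc(OC)c2)[nH]c2cc(OC)ccc2c1=O` gives > 21500 nM (a limit)
compound 2 `CCOC(=O)c1c(-c2cccc(OCC)c2)[nH]c2cc(OC)ccc2c1=O` gives > 21500 nM (a limit)
compound 3 `CCOC(=O)c1c(-c2cccc([N+](=O)[O-])c2)[nH]c2cc(OC)ccc2c1=O` gives > 21500 nM (a limit)

Compound 1 gives > 21500 nM as a limit and has no exact number. The whole measured set stands at the limit of > 21500 nM in this assay, at which 3 of the 3 values shown sit, and offers no reading below it.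

The next structure is compound 4 `CCOC(=O)c1c(-c2cccc(OC)c2)[nH]c2cc(SC)ccc2c1=O` with methylsulfanyl in place of methoxy on an aromatic carbon and the rest of compound 1 unchanged.

The measured steps are a step that the two limits leave unreadable from compound 1 to compound 2 and a step that the two limits leave unreadable from compound 1 to compound 3 and also a step that the two limits leave unreadable from compound 2 to compound 3 and none of them has a readable size. None of them makes this same exchange, so they bear on it only indirectly. No direction can be drawn from them, and compound 4 is expected to stay close to the same limit in this assay and may well be reported only as a limit. The expected step is a step that the limit leaves unreadable from compound 1 to compound 4 with no direction expected beyond the scatter.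

For compound 4 the estimate is 25000 nM with 12000 nM to 50000 nM as the expected range.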

Compound 4, half-maximal effective concentration: > 21500 nM
Compound 4: no number, only a limit (the forecaster's own chance of this, stated with the estimate: 85%); the middle value does not contradict the limit.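

In this assay compound 4 gives > 21500 nM, a limit and not a number, so the step from compound 1 to compound 4 cannot be read. The compounds shown leave open whether any exchange on the shared core changes the value at all: the limit of > 21500 nM in this assay, at which 4 of the 4 values shown sit.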